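Aryl amide substituents on a fused bicyclic core: cytotoxicity notes

The source may report more compounds than this note shows. Statements on the series, on what has been measured and on what is new or still open speak of the compounds shown alone.

Measured so far:
compound 1 `CO[C@@H]1CC=C2N(c3ccc(C)cc3)C(=O)C[C@]2(c2ccccc2)O1` — 3500 nM
compound 2 `CO[C@@H]1CC=C2N(c3ccc([N+](=O)[O-])cc3)C(=O)C[C@]2(c2ccccc2)O1` — 9400 nM
compound 3 `CO[C@@H]1CC=C2N(c3c[nH]c4ccccc34)C(=O)C[C@]2(c2ccccc2)O1` — 8200 nM

All three share one core and differ only in the group on the amide-type nitrogen in the ring. In a functional assay on SK-N-SH cells (Homo sapiens) for cytotoxicity, read by sulforhodamine B assay, with a stated time of 48 h (on this read-out higher numbers stand for weaker inhibition and lower numbers for stronger inhibition), compound 1 gives the lowest of the three numbers. Compound 3 stands second highest; its value and that of compound 2 lie within the scatter of each other (a 1.1-fold lower number from compound 2 to compound 3 (0.06 log units; within the scatter)), while the step of a 2.3-fold higher number from compound 1 to compound 3 (0.37 log units; beyond the scatter) is beyond the scatter, as is a 2.7-fold higher number from compound 1 to compound 2 (0.43 log units; beyond the scatter).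

Compound 4 `CO[C@@H]1CC=C2N(c3cc(Cl)cc(Cl)c3)C(=O)C[C@]2(c2ccccc2)O1` is not yet measured. Its change from compound 3 is 3,5-dichlorophenyl in place of 1H-indol-3-yl on an amide-type nitrogen in a ring. Among the compounds with values here, no measured step covers a 3,5-dichlorophenyl group, so the expectation rests on the general spread: every aryl group tried so far, whether 4-methylphenyl, 4-nitrophenyl or 1H-indol-3-yl, has landed in a band spanning the modest steps above, and a dichlorophenyl group is taken to fall within that same band. A number near the middle of the three measured values is therefore expected for compound 4, with the step of a 1.6-fold lower number from compound 3 to compound 4 (0.21 log units; within the scatter) expected to stay within the scatter. The estimate for compound 4 in this assay is 5000 nM, with a range from 1800 nM to 14000 nM.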

Compound 4, half-maximal inhibitory concentration: 9670 nM
Compound 4: middle estimate off by 1.9-fold (0.29 log units), on the low side; the range from low to high includes it.
By their numbers in this assay, from the lowest: compound 1; then compounds 3, 2 and 4 (each within the scatter of the next).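

The 3,5-dichlorophenyl group joins a cluster in this assay: the steps of a 1.2-fold higher number from compound 3 to compound 4 (0.07 log units; within the scatter) and a 1.0-fold higher number from compound 2 to compound 4 (0.01 log units; within the scatter) show no separation among the three groups compared, so on this amide-type nitrogen in a ring, removing the hydrogen-bond donor and the five-membered aromatic ring of 1H-indol-3-yl, or exchanging 4-nitrophenyl for a ring bearing two chlorine atoms, leaves the number unresolved from its neighbours. Compound 1 alone goes against this clustering, since its 4-methylphenyl group gives the lowest number of the series, and the new step of a 2.8-fold higher number from compound 1 to compound 4 (0.44 log units; beyond the scatter) is of the same modest size as the two earlier steps away from that group. No measurement bears on why the 4-methylphenyl group stands apart.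

The compounds shown leave open whether the separation belongs to the methyl group itself or to substitution at that ring location, which an unsubstituted phenyl, a 4-ethylphenyl or a 4-methoxyphenyl group on the same nitrogen would help to test. Also open, as far as these compounds go, is how this position would respond to a group outside the aryl class, such as a benzyl group, a longer alkyl chain or an aryl ring carrying an amine or a carboxylic acid.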